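This account rests on a few compounds, and the source may have more. Where it says the series, first, only, none or still open, it means among the compounds named here.

Measured compounds, in an assay on HEK cells for antagonist activity at transient receptor potential cation channel subfamily V member 1 (Homo sapiens), read by FLIPR; a lower number here means a stronger inhibitor, a higher number a weaker inhibitor:
compound 1 `O=C(NCc1ccc(C(F)(F)F)nc1N1CCC(Cc2ccccc2)CC1)Nc1cccc2[nH]c(=O)ccc12` gives 1.59 nM
compound 2 `O=C(NCc1ccc(C(F)(F)F)nc1N1CCCC1)Nc1cccc2[nH]c(=O)ccc12` gives 0.94 nM
compound 3 `CCCCOc1nc(C(F)(F)F)ccc1CNC(=O)Nc1cccc2[nH]c(=O)ccc12` gives 4 nM

Compound 2 shows the lowest number of the three, though compound 1 sits within the scatter of it; compound 3 lies beyond the scatter, with a 4.3-fold higher number from compound 2 to compound 3 (0.63 log units; beyond the scatter). Compound 4 `CCCCCCOc1nc(C(F)(F)F)ccc1CNC(=O)Nc1cccc2[nH]c(=O)ccc12` has not yet been measured in this assay. It differs from compound 2 by hexyloxy in place of pyrrolidin-1-yl on an aromatic carbon. For the measured compounds named here, the one measured step that bears on this change is the one in which butoxy replaced the same pyrrolidin-1-yl at the same place, giving a 4.3-fold higher number from compound 2 to compound 3 (0.63 log units; beyond the scatter). Hexyloxy is a longer chain than butoxy, and no measured pair shows what lengthening the chain does at this position; the step to compound 3 is the only guide. For compound 4 a modest rise in the number, of about the size seen for compound 3, is therefore expected, a 5.3-fold higher number from compound 2 to compound 4 (0.73 log units; beyond the scatter). Compound 4 is expected to give 5 nM in this assay, with a range from 2 nM to 15 nM.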

Compound 4, half-maximal inhibitory concentration: 3.19 nM
Compound 4: middle estimate off by 1.6-fold (0.20 log units), on the high side, and the stated range covers the measured number.
By their numbers in this assay, from the lowest: compounds 2, 1, 4 and 3 (each within the scatter of the next, the first and the last beyond it).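

In this assay, hexyloxy on the aromatic carbon next to the ring nitrogen also falls short of pyrrolidin-1-yl, with a 3.4-fold higher number from compound 2 to compound 4 (0.53 log units; beyond the scatter), so the gap seen with butoxy is not confined to a single chain. The two chains cannot be told apart, with a 1.3-fold lower number from compound 3 to compound 4 (0.10 log units; within the scatter), so the added ethyl gives no readable difference at this place. Nothing measured here accounts for the gap between pyrrolidin-1-yl and the two chains.

From the compounds shown here alone, whether a shorter chain such as methoxy or a longer one such as octyloxy would stay level with these two remains open. Going by these compounds, an open-chain amine such as diethylamino would help separate the effect of the linking nitrogen from that of the ring, and this also remains open.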